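The compounds below may be only part of what the source reports. "The series", "measured", "known", "first", "only" and "open" are said of these compounds alone.

Measured so far in a functional assay on A-375 cells (Homo sapiens) for antiproliferative activity, read by CCK-8 assay, with a stated time of 72 h; on this read-out lower numbers stand for stronger inhibition and higher numbers for weaker inhibition:
compound 1 `CCC(C)n1cnc2c(NCc3ccc(C(=O)Nc4ccccc4N)cc3)nc(Cl)nc21` gives 2880 nM;
compound 2 `Nc1ccccc1NC(=O)c1ccc(Cn2cnc3c(Nc4ccccc4)nc(Cl)nc32)cc1` gives 2800 nM;
compound 3 `Nc1ccccc1NC(=O)c1ccc(Cn2cnc3c(Nc4ccc(-c5ccccn5)cc4)nc(Cl)nc32)cc1` gives 18500 nM.

Compound 1 stands second highest of the three numbers in this assay; its number and that of compound 2 lie within the scatter of each other, while compound 3 sits clearly higher. Among the compounds with values here, the single measured step, a 6.6-fold higher number from compound 2 to compound 3 (0.82 log units; beyond the scatter), concerns pyridin-2-yl on an aromatic carbon and does not touch the place altered here. Compound 4 `Nc1ccccc1NC(=O)c1ccc(CNc2nc(Cl)nc3c2ncn3C2CCCC2)cc1` differs from compound 1 by cyclopentyl in place of sec-butyl on an aromatic nitrogen. Within the data shown here, no measured step bears on an exchange at this aromatic nitrogen, so in this assay no shift beyond the scatter is expected in either direction. Compound 4 is therefore estimated at 2600 nM, with a range from 1000 nM to 6500 nM. The step expected is a 1.1-fold lower number from compound 1 to compound 4 (0.04 log units; within the scatter).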

Compound 4, half-maximal inhibitory concentration: 2790 nM
Compound 4: middle estimate off by 1.1-fold (0.03 log units), on the low side, within the range that was stated.
By their numbers in this assay, from the lowest: compounds 4, 2 and 1 (each within the scatter of the next); then compound 3.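

In this assay the exchange on the aromatic nitrogen gives a 1.0-fold lower number from compound 1 to compound 4 (0.01 log units; within the scatter), so a five-membered carbon ring and open-chain sec-butyl read alike at this place. Within the data shown here, this is the only measured step at this aromatic nitrogen, and it shows that the added ring leaves the number within the scatter. Nothing available explains this equivalence.

On these data alone, whether a group carrying an amine or a carboxylic acid on this nitrogen would also leave the number unchanged remains open. So does whether a longer chain would.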